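Fluoro in Place of Trifluoromethyl: Expected Tolerance of Compound 4

The source may report more compounds than this note shows. Statements on the series, on what has been measured and on what is new or still open speak of the compounds shown alone.

Three compounds have been measured in an ADME assay on HEK293 cells (Homo sapiens) for cytotoxicity, read by resazurin assay, with a stated time of 48 h; a higher number here means that more compound is tolerated, a lower number that less compound is tolerated:

Compound 1 `O=S(=O)(Nc1ccc(-c2nc3ccccc3o2)cc1)c1ccccc1C(F)(F)F` gives > 100000 nM.
Compound 2 `O=S(=O)(Nc1ccc2oc(-c3ccccc3)nc2c1)c1ccc(Cl)c(C(F)(F)F)c1` gives 66000 nM.
Compound 3 `C=Cc1ccc(S(=O)(=O)Nc2ccc3oc(-c4ccccc4)nc3c2)cc1` gives 53000 nM.

The value of compound 1 is a limit of this assay, not a number; it sits at the limit of > 100000 nM in this assay, at which 1 of the 3 values shown sits. Compound 2 and compound 3 each give a number, and those two numbers lie within the scatter of each other. Among the compounds with values here, no pair among the measured compounds differs in a single place, so no measured step is available to guide the next change.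

Compound 4 `O=S(=O)(Nc1ccc(-c2nc3ccccc3o2)cc1)c1ccccc1F` differs from compound 1 in one place: fluoro in place of trifluoromethyl on an aromatic carbon. The change is small, and the remainder of the structure is unchanged. Within the data shown here, nothing among the measured compounds points to a shift in this assay from this exchange, so the step is expected to lie within the scatter, and there is a fair chance that compound 4 also returns only a limit.

Compound 4 is therefore expected to give about 100000 nM in this assay, with a range from 40000 nM to 300000 nM, which amounts to an expected step of a number no higher from compound 1 to compound 4 (the limit leaves the size open).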

Compound 4, half-maximal cytotoxic concentration: > 100000 nM
Compound 4: a limit, no number; the forecaster's own chance of this, stated with the estimate: 55%; the middle value sits exactly at the limit.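

Compound 1 and compound 4 each return only a limit, not a number, in this assay, so no step can be read from the exchange of trifluoromethyl for fluoro: the limit of > 100000 nM in this assay, at which 2 of the 4 values shown sit. The compounds shown leave open whether fluoro in place of trifluoromethyl on an aromatic carbon changes tolerance at all, and by how much.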